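Replacing cyano with 1,3-benzothiazol-2-yl on a shared core

The compounds below may be only part of what the source reports. "The series", "measured", "known", "first", "only" and "open" are said of these compounds alone.

Three related compounds have been measured so far: compound 1 `CC(=O)c1ccc(NCc2cncn2Cc2ccc(-c3ccccc3)cc2)cc1-c1ccccc1`, compound 2 `N#Cc1ccc(NCc2cncn2Cc2ccc(-c3ccccc3)cc2)cc1-c1ccccc1` and compound 3 `N#Cc1ccc(NCc2cncn2Cc2ccc(-c3ccccc3)cc2N)cc1-c1ccccc1`. In a toxicity assay on NIH3T3 cells (Mus musculus) for cytotoxicity, read by resazurin assay (on this read-out higher numbers stand for an effect only at larger amounts of compound and lower numbers for an effect already at smaller amounts), compound 2 gives > 1000 nM, which is a limit of the assay and not a number. Compound 1 gives > 10000 nM in this assay, and this too is a limit. Compound 3 gives > 1000 nM in this assay, again a limit. Compound 2 therefore has no exact place on the scale.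

The next compound, compound 4 `c1ccc(-c2ccc(Cn3cncc3CNc3ccc(-c4nc5ccccc5s4)c(-c4ccccc4)c3)cc2)cc1`, has not been measured yet. It differs from compound 2 by one change: 1,3-benzothiazol-2-yl in place of cyano on an aromatic carbon. The measured step that touches the same carbon is a step that the two limits leave unreadable from compound 1 to compound 2, where cyano took the place of acetyl. The other measured step, a step that the two limits leave unreadable from compound 2 to compound 3, put amino in place of hydrogen on an aromatic carbon. Neither step has a readable size, so neither gives a direction for the new change. The expectation rests mainly on the limit of compound 2, > 1000 nM. The estimated change in this assay is a step that the limit leaves unreadable from compound 2 to compound 4, and it carries no measured size behind it. For compound 4 the expected value is 5000 nM, with an estimated range from 1000 nM to 20000 nM.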

Compound 4, half-maximal effective concentration: > 1000 nM
Compound 4: a limit, no number (the forecaster's own chance of this, stated with the estimate: 65%); the middle value lies beyond the limit too.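

Among the compounds shown here, neither the step from compound 2 to compound 4 nor the one from compound 1 to compound 4 can be read, as all three compounds give limits and not numbers. The compounds shown leave open at what concentration any of them has an effect in this assay, and whether changing the group on the shared core shifts that concentration at all.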